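The source may hold more compounds than are shown below. What is called first, only, known or untested is meant among the compounds shown, and "the series" means these compounds.

In a functional assay on KG-1 cells (Homo sapiens) for cytotoxicity, read by luminescence and CellTiter-Glo, with a stated time of 3 days (on this read-out higher numbers stand for weaker inhibition and lower numbers for stronger inhibition), compound 1 `O=C(Nc1ccc(C(F)(F)F)cc1)c1cc(Cl)ccc1O` gives 740 nM, while compound 2 `N#Cc1ccc(NC(=O)c2cc(-c3cccnc3)ccc2O)cc1` gives 8330 nM, the higher of the two numbers by a gap beyond the scatter. Compound 3 `N#Cc1ccc(NC(=O)c2cc(Cl)ccc2O)cc1` differs from compound 2 in one place, with chloro in place of pyridin-3-yl on an aromatic carbon. Compound 1 also carries chloro and reads 740 nM, so a clearly lower number, beyond the scatter, is expected for compound 3 in this assay. The estimated change is a 6.9-fold lower number from compound 2 to compound 3 (0.84 log units; beyond the scatter). For compound 3 the expected value is 1200 nM, with an estimated range of 350 nM to 4000 nM.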

Compound 3, half-maximal inhibitory concentration: 1860 nM
For compound 3 the middle estimate is 1.6-fold (0.19 log units) below the measured one, within the range that was stated.
By their numbers in this assay, from the lowest: compound 1; then compound 3; then compound 2.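

In this assay, chloro in place of pyridin-3-yl, on the carbon para to a hydroxy group, gives a 4.5-fold lower number from compound 2 to compound 3 (0.65 log units; beyond the scatter), so the group at this position clearly shifts the read-out. The chloro compounds also show that a second place counts: cyano in place of trifluoromethyl gives a 2.5-fold higher number from compound 1 to compound 3 (0.40 log units; beyond the scatter). No measurement here explains either step.

On these data alone, whether an amine or a carboxylic acid at this position would give a lower or a higher number stays open. So does whether the pyridin-3-yl step would be the same size with trifluoromethyl in place of cyano.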